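This account rests on a few compounds, and the source may have more. Where it says the series, first, only, none or still open, it means among the compounds named here.

Measured compounds and their values in an assay on membranes from HeLa cells for displacement of a labelled ligand from adenosine receptor A3 (Homo sapiens), read by scintillation counting, with a stated time of 180 min, tested at 1 uM; a lower number here means less inhibition, a higher number more inhibition at the concentration tested (going by the name of the read-out):

Compound 1, `CCCC(=O)C1=C(C)NC(=O)NC1c1ccco1`, gives 1%.
Compound 2, `CC1=C(C(=O)CC(C)C)C(c2ccco2)NC(=O)N1`, gives 31%.
Compound 3, `CCC(CC)OC(=O)C1=C(C)NC(=O)NC1c1ccoc1`, gives 5%.

Compounds 1 and 2 share a core and differ in one place: hydrogen in place of methyl on a saturated chain carbon bound to two saturated chain carbons. Across that change the read-out moves by a number 30 percentage points lower from compound 2 to compound 1 (beyond the scatter), a step beyond the scatter, with compound 1 at the low end. Compound 3 carries a different core; the difference between the two cores is not broken down here. Among the three, compound 3 sits second, and its gap to compound 1 lies within the scatter, so no order between compound 1 and compound 3 is claimed; its gap to compound 2 lies beyond the scatter.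

Compound 4, `CCC(C)OC(=O)C1=C(C)NC(=O)NC1c1ccoc1`, has not yet been measured. It stands to compound 3 as compound 1 stands to compound 2: hydrogen in place of methyl on a saturated chain carbon, two bonds along the chain from an oxygen next to a carbonyl group. Among the compounds with values here, this is the same kind of change as the one seen from compound 2 to compound 1, not the same change: there the place was a saturated chain carbon bound to two saturated chain carbons, here it is a saturated chain carbon two bonds along the chain from an oxygen next to a carbonyl group, and the cores differ as well.

Within the data shown here, the only measured precedent is the step of a number 30 percentage points lower from compound 2 to compound 1 (beyond the scatter), which lowered the read-out. Compound 3 already starts from a low value, 5%, so little room remains downward. The expected step from compound 3 to compound 4 in this assay is therefore a number 2 percentage points lower from compound 3 to compound 4 (within the scatter), small and within the scatter. Compound 4 is estimated at 3%, with a likely range from -5% to 12%. This rests on one precedent only, on a different core, and is held loosely.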

Compound 4, a percentage reported as inhibition, at one concentration (the size of the read-out at that concentration, not a potency): 11%
Beside the measured number, compound 4's estimate is 8 percentage points below it; measured number inside the range.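

In this assay, hydrogen in place of methyl does not carry over as one fixed step from one core to the other: the same change on two cores in this assay, a number 30 percentage points lower (beyond the scatter) from compound 2 to compound 1 and a number 6 percentage points higher (within the scatter) from compound 3 to compound 4, 36 percentage points apart, beyond the scatter of two such steps

The new step alone reads a number 6 percentage points higher from compound 3 to compound 4 (within the scatter), so on this core the change leaves nothing that can be told apart from repeat measurements, whereas the earlier step, a number 30 percentage points lower from compound 2 to compound 1 (beyond the scatter), starts from the highest value among these compounds, with compound 2 at 31%, and compound 3 starts from only 5%. This does not show that the core is what separates the two steps, since the place differs as well, a saturated chain carbon bound to two saturated chain carbons in one pair and a saturated chain carbon two bonds along the chain from an oxygen next to a carbonyl group in the other, and two pairs at a single concentration give no rule for the series.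

Open, going by these compounds, is what the same change does at one and the same place on both cores, which is what would separate core from place. Also open, on these data alone, is whether a longer chain, an amine or a carboxylic acid at this place would lift the read-out on either core.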